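Propargyl oxadiazole series: fluoro in place of methoxy

This account rests on a few compounds, and the source may have more. Where it says the series, first, only, none or still open, it means among the compounds named here.

Measured so far:
compound 1, `C#CCOc1ccc(-c2noc(NC3CCCCC3)n2)cc1`: 5.3 ug/mL
compound 2, `C#CCN(c1nc(-c2ccc(OC)cc2)no1)C1CCCCC1`: 1 ug/mL

In a functional assay on NCI-H460 cells (Homo sapiens) for inhibition, read by MTT assay, with a stated time of 72 h (a lower number here means a stronger inhibitor, a higher number a weaker inhibitor), compound 2 gives 1 ug/mL, the lowest of the two numbers measured. Compound 1 gives 5.3 ug/mL, a higher number, and the gap between the two lies beyond the scatter. Going by the values given here, the two structures differ in more than one place, so no single step is drawn between them.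

Compound 3, `C#CCN(c1nc(-c2ccc(F)cc2)no1)C1CCCCC1`, has not been measured in this assay. Against compound 2 the change is fluoro in place of methoxy on an aromatic carbon. Nothing measured in the series bears on this exchange. The change is expected to be small, a 1.5-fold higher number from compound 2 to compound 3 (0.18 log units; within the scatter), toward a slightly higher number and likely not beyond the scatter. Compound 3 is therefore estimated at 1.5 ug/mL in this assay, with a range from 0.5 ug/mL to 5 ug/mL.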

Compound 3, half-maximal inhibitory concentration: 1.16 ug/mL
Beside the measured number, compound 3's estimate is 1.3-fold (0.11 log units) above it; the measured number falls inside the stated range.
By their numbers in this assay, from the lowest: compounds 2 and 3 (each within the scatter of the next); then compound 1.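

In this assay, going by these compounds alone, fluoro in place of methoxy on an aromatic carbon para to a large group gives a 1.2-fold higher number from compound 2 to compound 3 (0.06 log units; within the scatter), the first single-place reading. At this position the two groups cannot be told apart by this read-out, even though the hydrogen-bond acceptor counted for methoxy is not counted for fluoro. No measurement shown accounts for this result.

Going by these compounds, only these two groups have been compared at this position, so it remains open whether an amine, a carboxylic acid or a longer alkoxy chain there would stay within the scatter of compound 2 and compound 3. On these data alone, it is also open whether the same exchange would read the same way on a compound with a different group on the shared core.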